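Working notes: from compound 2 to compound 3

A few compounds are considered here, and "the series" means these few. Any claim that something is new, unique, unknown or untested is made for them only; others in the source may bear on it.

Compound 1 `COc1cc(N2C(=O)[C@@H](Oc3ccccc3)[C@H]2c2cccc([N+](=O)[O-])c2)cc(OC)c1OC`: 30000 nM
Compound 2 `COc1cc(N2C(=O)[C@@H](Oc3ccccc3)[C@H]2c2cc(O)c(OC)c([N+](=O)[O-])c2)cc(OC)c1OC`: 69000 nM

In a functional assay on MCF7 cells (Homo sapiens) for antiproliferative activity, read by MTT assay, with stated times of 24 h and 72 h (a higher number here means a weaker inhibitor, a lower number a stronger inhibitor), compound 2 gives 69000 nM as the higher of the two numbers, which makes it the weaker inhibitor of the pair. Compound 3 `COc1cc(N2C(=O)[C@@H](Oc3ccccc3)[C@H]2c2ccc(N)cc2)cc(OC)c1OC` keeps the shared core and carries 4-aminophenyl on a saturated ring carbon of a four-membered non-aromatic ring with 1 nitrogen. The change is a group of 7 heavy atoms (6 carbon, 1 nitrogen; one six-membered aromatic ring of carbon only) in place of a group of 12 heavy atoms (7 carbon, 1 nitrogen, 4 oxygen; one six-membered aromatic ring of carbon only), on a saturated ring carbon in full. Among the measured compounds shown here, only one measured step bears on this: a 2.3-fold higher number from compound 1 to compound 2 (0.36 log units; beyond the scatter) is modest, and it came with the larger group entering. Here a smaller group enters, so a modest move towards a lower number is expected in this assay on that single step. The expected size is a 2.8-fold lower number from compound 2 to compound 3 (0.44 log units; beyond the scatter) and remains uncertain. For compound 3 the estimated value is 25000 nM with an expected range from 6000 nM to 80000 nM in this assay.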

Compound 3, half-maximal inhibitory concentration: 160000 nM
Beside the measured number, compound 3's estimate is 6.4-fold (0.81 log units) below it; measured number outside the range, above it.
By their numbers in this assay, from the lowest: compound 1; then compound 2; then compound 3.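

In this assay the smaller 4-aminophenyl group at this saturated ring carbon gives a 2.3-fold higher number from compound 2 to compound 3 (0.37 log units; beyond the scatter) and so does not follow the earlier step, in which the larger group also gave a higher number. Replacing 3-nitrophenyl with 4-aminophenyl gives a 5.3-fold higher number from compound 1 to compound 3 (0.73 log units; beyond the scatter) and places compound 3 highest of the three, so heavy-atom count alone does not order this series, with compound 1 and compound 3 both lower in count than compound 2 yet on opposite sides of it. No measurement given here explains either step.

On these data alone, whether an unsubstituted phenyl or a phenyl bearing a carboxylic acid at this ring carbon would give a number below that of compound 1 remains open. The three groups shown also cannot separate the contribution of the amine from that of the nitro group.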